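This account rests on a few compounds, and the source may have more. Where it says the series, first, only, none or still open, it means among the compounds named here.

Measured in a toxicity assay on Vero C1008 cells (Chlorocebus sabaeus) for cytotoxicity, read by CellTiter-Glo; a higher number here means that more compound is tolerated, a lower number that less compound is tolerated:
- Compound 1 `COc1cccc2[nH]c(C(=O)N[C@@H](CC(C)C)C(=O)N[C@H](C#N)C[C@@H]3CCCNC3=O)cc12`: > 200000 nM (a limit)
- Compound 2 `COc1cccc2[nH]c(C(=O)N[C@@H](CC(C)C)C(=O)N[C@H](C#N)C[C@@H]3CCNC3=O)cc12`: > 200000 nM (a limit)

Compound 1 stands at a limit and has no number. Going by the values given here, the same is true of the only other measured compound, as the limit of > 200000 nM in this assay, at which 2 of the 2 values shown sit, shows.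

Compound 3 `COc1cccc2[nH]c(C(=O)N[C@@H](CC(C)C)C(=O)N[C@@H](C[C@@H]3CCCNC3=O)C(=O)CO)cc12` carries (hydroxymethyl)carbonyl in place of cyano on a saturated chain carbon bound to an amide-type nitrogen and a saturated chain carbon.

Among the compounds with values here, the only measured step is a step that the two limits leave unreadable from compound 1 to compound 2. It alters a different group and has no readable size, so it offers no size to carry over to this change. With nothing pointing to a shift, no step beyond the scatter is expected in this assay. The estimated step is a number no higher from compound 1 to compound 3 (the limit leaves the size open). For compound 3 the expected value is 200000 nM, with an estimated range of 80000 nM to 400000 nM.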

Compound 3, half-maximal cytotoxic concentration: > 200000 nM
Compound 3: no number, only a limit (the forecaster's own chance of this, stated with the estimate: 80%); the middle value lies on the limit itself.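

In this assay compound 3 gives > 200000 nM, which is a limit and not a number. No step from compound 1 to compound 3 can therefore be read: the limit of > 200000 nM in this assay, at which 3 of the 3 values shown sit.

The compounds shown leave open whether (hydroxymethyl)carbonyl in place of cyano shifts the tolerated concentration at all.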